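Aryl Amine Swapped for a Dialkyl Amine on the Shared Core

This account rests on a few compounds, and the source may have more. Where it says the series, first, only, none or still open, it means among the compounds named here.

Two compounds of this series have numbers in hand. Compound 1 `O=C1C=C(NC2CCCC2)C(=O)c2c1nc1n2[C@H]2OC[C@@H](O)[C@H]2OC1` carries a cyclopentyl group on an amine nitrogen; in a functional assay on HeLa cells (Homo sapiens) for inhibition, read by sulforhodamine B assay (a higher number here means a weaker inhibitor, a lower number a stronger inhibitor), compound 1 reaches only a limit, > 16000 nM. Among the measured compounds shown here, compound 2 `O=C1C=C(Nc2ccc(Br)cc2)C(=O)c2c1nc1n2[C@H]2OC[C@@H](O)[C@H]2OC1` carries a 4-bromophenyl group on that nitrogen, and in this assay compound 2 gives 3830 nM, the only true number among the two values shown. The other value, that of compound 1, is a limit (the limit of > 16000 nM in this assay, at which 1 of the 2 values shown sits). The measured step of an at least 4.1-fold lower number from compound 1 to compound 2 (0.62 log units; beyond the scatter) came from 4-bromophenyl in place of cyclopentyl on an amine nitrogen. Compound 3 `CCCN(CCC)C1=CC(=O)c2nc3n(c2C1=O)[C@H]1OC[C@@H](O)[C@H]1OC3` has not been measured; it differs from compound 2 by dipropylamino in place of (4-bromophenyl)amino on a double-bonded ring carbon. For the measured compounds named here, since the one measured step, an at least 4.1-fold lower number from compound 1 to compound 2 (0.62 log units; beyond the scatter), ran from a non-aromatic to an aromatic substituent, the reverse direction here is expected to weaken inhibition, possibly back toward the limit. Compound 3 is estimated at 12000 nM in this assay, in a range from 4000 nM to 40000 nM, an expected step of a 3.1-fold higher number from compound 2 to compound 3 (0.50 log units; beyond the scatter).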

Compound 3, half-maximal inhibitory concentration: > 16000 nM
Compound 3 ended at the assay's limit (the forecaster's own chance of this, stated with the estimate: 45%); middle value at least 1.3-fold (0.12 log units) from the limit.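

The change from (4-bromophenyl)amino to dipropylamino on a double-bonded ring carbon gave an at least 4.1-fold higher number from compound 2 to compound 3 (0.62 log units; beyond the scatter) in this assay. With this result, two different non-aromatic amines have been set against the single aryl amine, and in both cases the aryl amine has the lower number, although dipropylamino also differs by having no hydrogen-bond donor on the nitrogen. The step from compound 1 to compound 3 cannot be read, since each compound's value is a limit: the limit of > 16000 nM in this assay, at which 2 of the 3 values shown sit.

The compounds shown do not separate the contributions of the aromatic ring, the bromine and the hydrogen on the nitrogen to the lower number of compound 2. A plain phenylamino group, or a methyl(4-bromophenyl)amino group with no hydrogen on that nitrogen, would address these open points.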